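From a Bromophenyl Arm to a Naphthyl Arm

The source may report more compounds than this note shows. Statements on the series, on what has been measured and on what is new or still open speak of the compounds shown alone.

Compound 2 `O=C(/C=C/c1ccccc1Br)Nc1ccc2ncnc(Nc3cccc(Cl)c3)c2c1` gives 5.63 ug/mL in a functional assay on A549 cells (Homo sapiens) for antiproliferative activity, read by MTT assay, with a stated time of 48 h; on this read-out lower numbers stand for stronger inhibition and higher numbers for weaker inhibition. Within the data shown here, that is the higher of the two numbers measured so far; the other, from compound 1 `O=C(/C=C/c1cccs1)Nc1ccc2ncnc(Nc3cccc(Br)c3)c2c1`, is 4.66 ug/mL, and the two lie within the scatter of each other, so neither can be called the stronger. Compound 3 `O=C(/C=C/c1cccc2ccccc12)Nc1ccc2ncnc(Nc3cccc(Cl)c3)c2c1` has not yet been measured. It differs from compound 2 in one place: naphthalen-1-yl in place of 2-bromophenyl on a double-bonded chain carbon bound to a double-bonded chain carbon. Among the measured compounds shown here, nothing among the measured compounds shows what such a swap does on this shared core, so the expectation can only lean on the values already in hand. The step of a 1.1-fold lower number from compound 2 to compound 3 (0.05 log units; within the scatter) is expected to be small, in either direction, and most likely not beyond the scatter. Compound 3 is therefore estimated to give 5 ug/mL in this assay, with a range from 2 ug/mL to 12 ug/mL.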

Compound 3, half-maximal inhibitory concentration: 1.49 ug/mL
For compound 3 the middle estimate is 3.4-fold (0.53 log units) above the measured one; the measured number lies below the stated range.
By their numbers in this assay, from the lowest: compound 3; then compounds 1 and 2 (each within the scatter of the next).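

In this assay, putting naphthalen-1-yl in place of 2-bromophenyl on a double-bonded chain carbon bound to a double-bonded chain carbon gives a 3.8-fold lower number from compound 2 to compound 3 (0.58 log units; beyond the scatter), a step beyond the scatter. This shows that the group at this position can shift the number on the shared core, which the earlier pair of values could not show, and here the lower number goes with the group holding 2 aromatic rings and no bromine. Nothing measured here explains the step.

This single swap removes the bromine and adds a second ring at once, so the compounds shown cannot say which of the two changes matters. As far as these compounds go, a plain phenyl group would help separate them, and an amine or a carboxylic acid on the ring at this position remains untested here.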